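Halogenated phenyl variation on the sulfonyl sulfur

A few compounds are considered here, and "the series" means these few. Any claim that something is new, unique, unknown or untested is made for them only; others in the source may bear on it.

Measured in an assay on MDA-MB-231 cells for displacement of a labelled ligand from C-X-C chemokine receptor type 4 (Homo sapiens), read by fluorescence and microscopy, with stated times of 10 min and 30 min; a higher number here means that more compound is needed for the effect, a lower number that less compound is needed:
compound 1 `O=C(NCc1ccc(CNS(=O)(=O)c2ccccc2F)cc1)c1cccnc1` gives 100 nM
compound 2 `O=C(NCc1ccc(CNS(=O)(=O)c2ccc(F)cc2)cc1)c1cccnc1` gives 100 nM

Compound 2 stands level with compound 1 at the digits recorded; the step of no change at the digits printed from compound 1 to compound 2 (within the scatter) lies within the scatter. Among the measured compounds shown here, the only measured step in the set thus changes where the fluorine sits on the phenyl attached to the sulfonyl sulfur and leaves the effective concentration unchanged.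

Compound 3 `O=C(NCc1ccc(CNS(=O)(=O)c2cccc(Cl)c2)cc1)c1cccnc1` is not yet measured. Its change from compound 2 is 3-chlorophenyl in place of 4-fluorophenyl on a sulfonyl sulfur. For the measured compounds named here, the one step that bears on this, no change at the digits printed from compound 1 to compound 2 (within the scatter), shifted a halogen without effect; no measured step exchanges one halogen for another, so the size of such an exchange is unknown here. Given compound 2 and the flat step from compound 1, no movement beyond the scatter in this assay is expected. For compound 3 the expected value is 100 nM, with a range of 50 nM to 220 nM, meaning an expected step of no change at the digits printed from compound 2 to compound 3 (within the scatter).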

Compound 3, effective concentration (reported as EC, without a stated level of effect): 100 nM
Estimate against measurement, compound 3: no gap at the digits printed; low and high end bracket the measured number.
By their numbers in this assay, from the lowest: compounds 1, 2 and 3 (each within the scatter of the next).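

In this assay, replacing fluorine with chlorine while also moving the halogen gives no change at the digits printed from compound 2 to compound 3 (within the scatter), and the same holds against the other fluorinated compound, with no change at the digits printed from compound 1 to compound 3 (within the scatter). A halogen exchange on the phenyl at the sulfonyl sulfur therefore adds no detectable movement to the flat result already seen for a shift of fluorine alone, and the read-out does not separate 2-fluorophenyl, 4-fluorophenyl and 3-chlorophenyl. Nothing available offers an explanation for this flat result.

From the compounds shown here alone, whether the flat response extends beyond halogenated phenyl groups remains open, for example to a phenyl carrying an amine or a carboxylic acid, or to a longer alkyl chain on the sulfonyl sulfur in place of the phenyl. Going by these compounds, the shared core is the same in all three compounds, so the effect of changes elsewhere also remains open.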